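Weak Antiproliferative Hydrazones: A Dimethylphenyl Variant

This account rests on a few compounds, and the source may have more. Where it says the series, first, only, none or still open, it means among the compounds named here.

Compound 1 `Cn1c(=O)c(=O)n(C2CCCC2)c2nc(N/N=C/c3ccc(O)cc3)ncc21` was tested in a functional assay on A549 cells (Homo sapiens) for antiproliferative activity, read by MTT assay; a lower number here means a stronger inhibitor, a higher number a weaker inhibitor. In this assay compound 1 gives > 100000 nM, which is a limit of the assay and not a number. Compound 2 `Cn1c(=O)c(=O)n(C2CCCC2)c2nc(N/N=C/c3ccc(C(F)(F)F)cc3)ncc21` gives 40600 nM in this assay. Compound 3 `Cn1c(=O)c(=O)n(C2CCCC2)c2nc(N/N=C/c3cccs3)ncc21` gives > 100000 nM in this assay, again a limit. Two of the three values therefore sit at the limit of > 100000 nM in this assay, at which 2 of the 3 values shown sit, and only the number for compound 2 stands clear of it. Among the compounds with values here, the one readable change is an at least 2.4-fold lower number from compound 1 to compound 2 (0.39 log units; beyond the scatter); in the other direction there is an at least 2.4-fold higher number from compound 2 to compound 3 (0.39 log units; beyond the scatter).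

Compound 4 `Cc1ccc(/C=N/Nc2ncc3c(n2)n(C2CCCC2)c(=O)c(=O)n3C)cc1C` has not yet been measured. It differs from compound 1 by 3,4-dimethylphenyl in place of 4-hydroxyphenyl on a carbon with a double bond to nitrogen. Within the data shown here, the step that bears on this is the one from compound 1 to compound 2, which also removes the hydroxy from the aromatic ring of compound 1 and gives an at least modest lowering. The exchange in compound 4 is expected to behave similarly, so the expected step is an at least 2.0-fold lower number from compound 1 to compound 4 (0.30 log units; that floor lies within the scatter). Compound 4 is estimated at 50000 nM, within a range from 20000 nM to 120000 nM.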

Compound 4, half-maximal inhibitory concentration: 30200 nM
Compound 4: the middle estimate sits 1.7-fold (0.22 log units) above what was measured; measured number inside the range.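

Removing the hydroxy now brings a readable gain with a second group on the phenyl ring, not only with trifluoromethyl, as there is an at least 3.3-fold lower number from compound 1 to compound 4 (0.51 log units; beyond the scatter), and the thiophene comparison gives an at least 3.3-fold lower number from compound 3 to compound 4 (0.51 log units; beyond the scatter). Compound 3 also lacks the hydroxy, so it goes against any rule that losing that group is enough, while the two substituted phenyl groups cannot be told apart, with a 1.3-fold lower number from compound 2 to compound 4 (0.13 log units; within the scatter). The gains from compound 1 and compound 3 are only floors, since both of those compounds give a limit and not a number: the limit of > 100000 nM in this assay, at which 2 of the 4 values shown sit.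

The compounds shown leave open whether both methyl groups of 3,4-dimethylphenyl are needed, or whether a single one would serve as well. They also leave open how an amine, a carboxylic acid or a longer chain on the phenyl ring would behave.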